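The source may report more compounds than this note shows. Statements on the series, on what has been measured and on what is new or still open speak of the compounds shown alone.

Compound 1 `C#Cc1cccc(Nc2ncnc3cc(OCCCCCn4ccnc4[N+](=O)[O-])c(OC)cc23)c1` is the reference point of the set. In a functional assay on A549 cells (Homo sapiens) for inhibition, read by sulforhodamine B assay, with a stated time of 72 h (a higher number here means a weaker inhibitor, a lower number a stronger inhibitor), compound 1 gives 180 nM. Compound 2 `C#Cc1cccc(Nc2ncnc3cc(OCCOCCn4ccnc4[N+](=O)[O-])c(OC)cc23)c1` differs from it by 2-(2-nitro-1H-imidazol-1-yl)ethoxy in place of 3-(2-nitro-1H-imidazol-1-yl)propyl on a saturated chain carbon, two bonds along the chain from an oxygen on an aromatic ring, and in this assay compound 2 gives 6430 nM; the step of a 36-fold higher number from compound 1 to compound 2 (1.55 log units; beyond the scatter) is large. Compound 3 `COc1cc2c(Nc3cccc(Br)c3)ncnc2cc1OCCCCCn1ccnc1[N+](=O)[O-]` keeps the chain of compound 1 and differs in the core by bromo in place of ethynyl on an aromatic carbon; in this assay compound 3 gives 8420 nM, the highest number of the three, and the step of a 47-fold higher number from compound 1 to compound 3 (1.67 log units; beyond the scatter) is likewise large. The numbers of compound 2 and compound 3 lie within the scatter of each other, so nothing separates them.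

Compound 4 `COc1cc2c(Nc3cccc(Br)c3)ncnc2cc1OCCOCCn1ccnc1[N+](=O)[O-]` has not been measured. Among the measured compounds shown here, it carries the core of compound 3 together with the chain of compound 2: relative to compound 3 the change is 2-(2-nitro-1H-imidazol-1-yl)ethoxy in place of 3-(2-nitro-1H-imidazol-1-yl)propyl on a saturated chain carbon, two bonds along the chain from an oxygen on an aromatic ring, the same change as the one from compound 1 to compound 2, made at the same place. The step expected here is a 4.2-fold higher number from compound 3 to compound 4 (0.62 log units; beyond the scatter), smaller than the measured 36-fold higher number from compound 1 to compound 2 (1.55 log units; beyond the scatter), since compound 3 already starts from 8420 nM and whether the two changes add in full cannot be read from three compounds. The estimate for compound 4 in this assay is 35000 nM, with a range from 9000 nM to 150000 nM, and there is a fair chance that only a limit is reported.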

Compound 4, half-maximal inhibitory concentration: 10100 nM
The estimate for compound 4 lay 3.5-fold (0.54 log units) above the measured number; the range from low to high includes it.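

In this assay, 2-(2-nitro-1H-imidazol-1-yl)ethoxy in place of 3-(2-nitro-1H-imidazol-1-yl)propyl does not carry its large step over from the core of compound 1 to the core of compound 3, where the step is a 1.2-fold higher number from compound 3 to compound 4 (0.08 log units; within the scatter), and the two steps differ: the same change on two cores in this assay, a 36-fold higher number (1.55 log units; beyond the scatter) from compound 1 to compound 2 and a 1.2-fold higher number (0.08 log units; within the scatter) from compound 3 to compound 4, 30-fold (1.47 log units) apart, beyond the scatter of two such steps

Read the other way, bromo in place of ethynyl on an aromatic carbon depends on the chain in the same way, with the step now a 1.6-fold higher number from compound 2 to compound 4 (0.20 log units; within the scatter), so the two changes do not add in this set: the same change on two cores in this assay, a 47-fold higher number (1.67 log units; beyond the scatter) from compound 1 to compound 3 and a 1.6-fold higher number (0.20 log units; within the scatter) from compound 2 to compound 4, 30-fold (1.47 log units) apart, beyond the scatter of two such steps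

Only compound 1 stands apart, while compound 2, compound 3 and compound 4 lie within the scatter of one another, but these four compounds cover a single pair of cores and a single pair of chains, so they neither explain the dependence nor show that it holds elsewhere in the series.

Open, as far as these compounds go, is whether the number of compound 1 depends on ethynyl specifically, which a chloro group or a nitrile in its place would address, and whether it depends on this exact chain, which a shorter chain, a longer chain or an amine within the chain would address. Also open, from the compounds shown here alone, is what the nitro group contributes, which a plain imidazole at the end of the chain would address.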